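Amino in place of propoxy on a carbonyl carbon

The source may report more compounds than this note shows. Statements on the series, on what has been measured and on what is new or still open speak of the compounds shown alone.

Compound 1 `CCOC(=O)c1ccc(-c2nn(Cc3cccc(Cl)c3)c3ccccc23)cc1`: 80 nM
Compound 2 `CCCn1nc(-c2ccc(C(=O)OCC)cc2)c2ccccc21`: 490 nM
Compound 3 `CCCOC(=O)c1ccc(-c2nn(Cc3ccccc3)c3ccccc23)cc1`: > 10000 nM (a limit)

In a functional assay on cells (Platelet, Homo sapiens) for inhibition (a lower number here means a stronger inhibitor, a higher number a weaker inhibitor), compound 3 reports only a limit, > 10000 nM, and not a number. Its position is thus (the limit of > 10000 nM in this assay, at which 1 of the 3 values shown sits).

Compound 4 `NC(=O)c1ccc(-c2nn(Cc3ccccc3)c3ccccc23)cc1` is not yet measured. It carries amino in place of the propoxy of compound 3 on a carbonyl carbon: amino in place of propoxy on a carbonyl carbon.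

Going by the values given here, no measured step touches that carbonyl carbon. Among the compounds with values here, the only step available, a 6.1-fold higher number from compound 1 to compound 2 (0.79 log units; beyond the scatter), lies elsewhere in the molecule and is modest, so it serves only as a rough gauge of size. Within the data shown here, with a limit as the starting point, no firm step can be derived. A modest move towards a lower number is expected, or none that can be seen, and compound 4 may also end at the limit.

The expected change is an at least 1.4-fold lower number from compound 3 to compound 4 (0.15 log units; that floor lies within the scatter).

Compound 4 is estimated at 7000 nM, with an expected range from 1500 nM to 30000 nM.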

Compound 4, half-maximal inhibitory concentration: > 10000 nM
Compound 4 ended at the assay's limit; the forecaster's own chance of this, stated with the estimate: 50%; at least 1.4-fold (0.15 log units) between middle value and limit.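

Compound 3 and compound 4 both stand at a limit of this assay and not at a number, so no step between them can be read: the limit of > 10000 nM in this assay, at which 2 of the 4 values shown sit.

The compounds shown leave open whether amino in place of propoxy on a carbonyl carbon changes inhibition at all.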